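A few compounds are considered here, and "the series" means these few. Any claim that something is new, unique, unknown or untested is made for them only; others in the source may bear on it.

Values in a functional assay on HeLa cells (Homo sapiens) for cytotoxicity, read by MTT assay; a higher number here means a weaker inhibitor, a lower number a stronger inhibitor:
- Compound 1 `C=C[C@@](C)(/C=C/c1ccc(O)cc1)CCC(O)C(C)(C)O` gives > 50000 nM (a limit)
- Compound 2 `C=C[C@@](C)(/C=C/c1ccc(O)cc1)CCC1OC1(C)C` gives > 50000 nM (a limit)
- Compound 3 `C=C[C@@](C)(/C=C/c1ccc(OC(C)=O)cc1)CCC=C(C)C` gives 18100 nM

Among the measured compounds shown here, compound 3 holds the only actual number, at 18100 nM. The other two entries are not numbers, and the ceiling they share is the limit of > 50000 nM in this assay, at which 2 of the 3 values shown sit. How far compound 3 stands from them therefore cannot be sized.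

The next step leads to compound 4 `C=C[C@@](C)(/C=C/c1ccc(OCC)cc1)CCC=C(C)C`, which differs from compound 3 in one place: ethyl in place of acetyl on an oxygen on an aromatic ring.

For the measured compounds named here, the only measured step is a step that the two limits leave unreadable from compound 1 to compound 2. That change lies on the chain, not on this oxygen, and it gives no size to carry over. Going by the values given here, no measured step touches the oxygen on the aromatic ring, so no direction can be argued, and no step beyond the usual scatter is expected in this assay. The expectation rests on compound 3 alone, at 18100 nM, and the range is kept wide for that reason.

The expected step is a 1.1-fold higher number from compound 3 to compound 4 (0.04 log units; within the scatter). Compound 4 is estimated at 20000 nM, with an expected range of 8000 nM to 50000 nM.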

Compound 4, half-maximal inhibitory concentration: > 50000 nM
Compound 4: a limit, no number; the forecaster's own chance of this, stated with the estimate: 25%; at least 2.5-fold (0.39 log units) between middle value and limit.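

In this assay, among the compounds shown here, ethyl in place of acetyl on an oxygen on an aromatic ring gives an at least 2.7-fold higher number from compound 3 to compound 4 (0.44 log units; beyond the scatter), the only readable step, since the step on the chain is left unreadable by its two limits. For the compounds shown here, this position is therefore not silent: with the rest of the structure unchanged, going from acetoxy to ethoxy produces a change beyond the scatter, and the series loses its only actual number. Compound 4 stands at a limit and not a number, so the step has a lower bound but no upper end: the limit of > 50000 nM in this assay, at which 3 of the 4 values shown sit.

Acetyl carries a double bond and a hydrogen-bond acceptor that ethyl lacks, and this single pair cannot tell whether either feature matters or whether the change depends on the whole group. A propanoyl or benzoyl group on this oxygen, or a free hydroxyl with the chain of compound 3, would help separate these readings and show how much of the value of compound 3 depends on the acetyl group itself.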